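A Double-Bond Geometry Change in a Cytotoxicity Series

A few compounds are considered here, and "the series" means these few. Any claim that something is new, unique, unknown or untested is made for them only; others in the source may bear on it.

Two compounds have been measured in a functional assay on XF498 cells (Homo sapiens) for cytotoxicity; on this read-out higher numbers stand for an effect only at larger amounts of compound and lower numbers for an effect already at smaller amounts:

compound 1, `C=CCCCCCCCC#CC#CC(O)CC(C)=O`, gives 4.45 ug/mL
compound 2, `C=CCCCCCC#CC#C/C(O)=C\C(C)=O`, gives 5.5 ug/mL

Compound 2 holds the highest of the two numbers, but compound 1 stands so close to it that the gap lies within the usual scatter, so the two show no difference that can be called an order. Compound 3, `C=CCCCCCC#CC#C/C(O)=C/C(C)=O`, has not yet been measured in this assay. Its relation to compound 2 is this: the two compounds have the same atoms and bonds and differ only in configuration as drawn: 1 of 1 stereo elements differ; a double bond is drawn E in compound 2 and Z in compound 3. Within the data shown here, no measured pair here is separated by a single change, so no step of this kind has yet been observed. Given that only the drawn geometry of one double bond changes, the step from compound 2 to compound 3 is expected to be no change at the digits printed from compound 2 to compound 3 (within the scatter), that is, nothing beyond the scatter. Compound 3 is therefore estimated at 5.5 ug/mL, with a range from 2.5 ug/mL to 12 ug/mL.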

Compound 3, concentration for half-maximal effect: 29.2 ug/mL
For compound 3 the middle estimate is 5.3-fold (0.73 log units) below the measured one; the measured number lies above the stated range.
By their numbers in this assay, from the lowest: compounds 1 and 2 (each within the scatter of the next); then compound 3.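

In this assay, the drawn geometry of this one double bond proves able to move the read-out on its own: going from E to Z gives a 5.3-fold higher number from compound 2 to compound 3 (0.73 log units; beyond the scatter). Among these compounds, no earlier measured pair was separated by a single change, so this is the first step that can be read, and the first sign that this double bond is a position where the read-out responds. With no atom entering or leaving, the step can be tied to geometry alone, because nothing else separates the two structures: the fact that compounds 2 and 3 differ only in the configuration as drawn

The compounds shown leave open whether the E and Z forms would stay this far apart with a carboxylic acid in place of the ketone, or with a longer chain. They also do not tell whether the same step would appear in any cell line other than the one used in this assay.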